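The source may report more compounds than this note shows. Statements on the series, on what has been measured and on what is new or still open speak of the compounds shown alone.

Measured so far in a functional assay on HCC827 cells (Homo sapiens) for inhibition, read by fluorescence and resazurin assay, with a stated time of 72 h; on this read-out higher numbers stand for weaker inhibition of growth and lower numbers for stronger inhibition of growth:
compound 1 `N[C@H]1CC[C@H](Nc2nc(Nc3ccc(Oc4nccs4)cc3)c3ncn(C4CCCC4)c3n2)CC1` gives 692 nM
compound 2 `NCCCCNc1nc(Nc2ccc(Oc3nccs3)cc2)c2ncn(C3CCCC3)c2n1` gives 6310 nM
compound 3 `N[C@H]1CC[C@H](Nc2nc(Nc3ccc(N4CCN(Cc5ccccc5)CC4)cc3)c3ncn(C4CCC(O)C4)c3n2)CC1` gives 840 nM

Compound 1 and compound 2 share a core and differ only by 4-aminobutyl in place of 4-aminocyclohexyl on a nitrogen on an aromatic ring. That single change gave a 9.1-fold higher number from compound 1 to compound 2 (0.96 log units; beyond the scatter), a step beyond the scatter. Compound 3 carries a different core; how it differs from compound 1 is not broken down here, and the values of compound 3 and compound 1 lie within the scatter of each other in this assay.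

Compound 4 `NCCCCNc1nc(Nc2ccc(N3CCN(Cc4ccccc4)CC3)cc2)c2ncn(C3CCC(O)C3)c2n1` is not yet measured. It relates to compound 3 by 4-aminobutyl in place of 4-aminocyclohexyl on a nitrogen on an aromatic ring, the same change that relates compound 2 to compound 1. Because the measured step of a 9.1-fold higher number from compound 1 to compound 2 (0.96 log units; beyond the scatter) was modest, the expected step for compound 4 is a 9.0-fold higher number from compound 3 to compound 4 (0.96 log units; beyond the scatter). Compound 4 is therefore estimated at 7600 nM in this assay, with a likely range of 2500 nM to 22000 nM.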

Compound 4, concentration for 50% growth inhibition: 2290 nM
The estimate for compound 4 lay 3.3-fold (0.52 log units) above the measured number, and the stated range ends above it.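

In this assay, 4-aminobutyl in place of 4-aminocyclohexyl gave a 2.7-fold higher number from compound 3 to compound 4 (0.44 log units; beyond the scatter) on the core of compound 3, so the number rose on both cores. The direction of the change carried over, but its size did not: the same change on two cores in this assay, a 9.1-fold higher number (0.96 log units; beyond the scatter) from compound 1 to compound 2 and a 2.7-fold higher number (0.44 log units; beyond the scatter) from compound 3 to compound 4, 3.3-fold (0.52 log units) apart, beyond the scatter of two such steps. For the compounds shown here, with only two pairs, this does not show which feature of the cores sets the size of the step, nor how the change would behave on a third core.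

The compounds shown leave open whether a longer chain in place of 4-aminobutyl would give a number closer to that of 4-aminocyclohexyl. They also leave open how an alcohol in place of the terminal amine would read on either core.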